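This account rests on a few compounds, and the source may have more. Where it says the series, first, only, none or still open, it means among the compounds named here.

Compound 2 `N#C/C(C(=O)Nc1ccc(Cl)cc1)=c1/s/c(=C\c2ccc(Cl)cc2)c(=O)n1-c1ccccc1` has been tested in a functional assay on HCT-116 cells (Homo sapiens) for cytotoxicity, read by sulforhodamine B assay, with a stated time of 48 h (a lower number here means a stronger inhibitor, a higher number a weaker inhibitor), where compound 2 gives 9150 nM. That is the higher of the two numbers available, yet compound 1 `N#C/C(C(=O)Nc1ccccc1)=c1/s/c(=C\c2ccccc2O)c(=O)n1-c1ccccc1`, which in this assay gives 7800 nM, sits within the scatter of compound 2, so the two cannot be told apart. Compound 3 `N#C/C(C(=O)Nc1ccc(Cl)cc1)=c1/s/c(=C\c2ccccc2O)c(=O)n1-c1ccccc1` is not yet measured. It differs from compound 2 in one place: 2-hydroxyphenyl in place of 4-chlorophenyl on a double-bonded chain carbon bound to an aromatic carbon, the same group that compound 1 carries. With compound 1 and compound 2 standing together, the step is expected to be a 1.1-fold lower number from compound 2 to compound 3 (0.04 log units; within the scatter), nothing beyond the scatter. Compound 3 is expected to give 8300 nM, within 4000 nM to 17000 nM.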

Compound 3, half-maximal inhibitory concentration: 6920 nM
The estimate for compound 3 lay 1.2-fold (0.08 log units) above the measured number, and the stated range covers the measured number.
By their numbers in this assay, from the lowest: compounds 3, 1 and 2 (each within the scatter of the next).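

In this assay, 2-hydroxyphenyl in place of 4-chlorophenyl on a double-bonded chain carbon bound to an aromatic carbon gives a step within the scatter (a 1.3-fold lower number from compound 2 to compound 3 (0.12 log units; within the scatter)), so this exchange leaves no readable change at this position. Chloro in place of hydrogen on an aromatic carbon also stays within the scatter (a 1.1-fold lower number from compound 1 to compound 3 (0.05 log units; within the scatter)). Nothing available explains either result.

From the compounds shown here alone, whether an amine or a carboxylic acid on the phenyl ring at this position would shift the number beyond the scatter remains open.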